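The source may hold more compounds than are shown below. What is called first, only, known or untested is meant among the compounds shown, and "the series" means these compounds.

Measured in a functional assay on MCF7 cells (Homo sapiens) for cytotoxicity, read by MTT assay, with a stated time of 72 h; a lower number here means a stronger inhibitor, a higher number a weaker inhibitor:
compound 1 `COc1cc2ncnc(Nc3ccc(F)c(Cl)c3)c2cc1NC(=O)/C=C/c1ccc(F)cc1Cl`: "not active" (no number reported)
compound 2 `N#Cc1ccc(/C=C/C(=O)Nc2cc3c(Nc4ccc(F)c(Cl)c4)ncnc3cc2O[C@H]2CCOC2)cc1`: 9830 nM

Within the data shown here, compound 2 gives the only number, 9830 nM. Compound 3 `COc1cc2ncnc(Nc3ccc(F)c(Cl)c3)c2cc1NC(=O)/C=C/c1ccc(C#N)cc1` follows from compound 2 by methyl in place of oxolan-3-yl on an oxygen on an aromatic ring, which reads (oxolan-3-yl)oxy to methoxy. Among the measured compounds shown here, no measured step shows this change. Compound 1 also carries methoxy and gives "not active" (no number reported), but it differs from compound 3 elsewhere, so this is weak guidance. A small move to a higher number in this assay is expected, possibly none beyond the scatter. The estimate implies a 1.3-fold higher number from compound 2 to compound 3 (0.12 log units; within the scatter). Compound 3 is expected at 13000 nM, with an estimated range of 4500 nM to 40000 nM.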

Compound 3, half-maximal inhibitory concentration: "not active" (no number reported)
Compound 3: no number reported, and the estimate cannot be compared.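

Among these compounds, compound 3 gives no number, so no step from compound 2 to compound 3 can be read. No available evidence bears on this result. In this assay the compounds shown leave open how (oxolan-3-yl)oxy to methoxy shifts the number.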